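Swapping Phenyl for Cycloheptyl: an Estimate Before Measurement

This account rests on a few compounds, and the source may have more. Where it says the series, first, only, none or still open, it means among the compounds named here.

Compound 1, `O=C(O)c1ccccc1-c1ccc(CCc2ncc(Cc3ccccc3F)[nH]2)cc1`, gives 177 nM in an in vitro functional assay on cells for agonist activity at Bombesin receptor subtype-3 (Homo sapiens), read by luminescence and calcium flux; on this read-out higher numbers stand for an effect only at larger amounts of compound and lower numbers for an effect already at smaller amounts.
Compound 2, `CCCCc1cnc(CCc2ccc(-c3ccccc3C(=O)O)cc2)[nH]1`, gives 2710 nM.
Compound 3, `O=C(O)c1ccccc1-c1ccc(CCc2ncc(Cc3ccccc3)[nH]2)cc1`, gives 205 nM.

Compound 3 stands second highest of the three numbers; compound 1 lies within the scatter of it, while compound 2 stands well above it. Compound 4, `O=C(O)c1ccccc1-c1ccc(CCc2ncc(CC3CCCCCC3)[nH]2)cc1`, differs from compound 3 by cycloheptyl in place of phenyl on a saturated chain carbon bound to an aromatic carbon. For the measured compounds named here, two measured steps bear on this change: a 13-fold lower number from compound 2 to compound 3 (1.12 log units; beyond the scatter) and a 15-fold higher number from compound 1 to compound 2 (1.18 log units; beyond the scatter), both showing that a six-membered aromatic ring on this carbon gives a markedly lower number than a short chain. Whether a seven-membered non-aromatic ring follows the aromatic ring or the chain is not settled by these three compounds, so a moderate rise is expected, a 3.4-fold higher number from compound 3 to compound 4 (0.53 log units; beyond the scatter). Compound 4 is therefore estimated at 700 nM, in the range 150 nM to 3500 nM.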

Compound 4, half-maximal effective concentration: 88 nM
For compound 4 the middle estimate is 8.0-fold (0.90 log units) above the measured one, and the stated range ends above it.
By their numbers in this assay, from the lowest: compounds 4, 1 and 3 (each within the scatter of the next, the first and the last beyond it); then compound 2.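

In the assay (this assay), the place on a saturated chain carbon bound to an aromatic carbon does not depend on an aromatic ring, since cycloheptyl in place of phenyl gives (a 2.3-fold lower number from compound 3 to compound 4 (0.37 log units; beyond the scatter)) and cycloheptyl in place of propyl gives (a 31-fold lower number from compound 2 to compound 4 (1.49 log units; beyond the scatter)). Against 2-fluorophenyl, the step (a 2.0-fold lower number from compound 1 to compound 4 (0.30 log units; within the scatter)) does not separate the two groups. Nothing available here explains these results.

On these data alone, whether cyclohexyl or a smaller saturated ring would behave like cycloheptyl remains open. So does the effect of an amine or a carboxylic acid on that ring.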